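Compound 2 gains a (trichloromethyl)sulfanyl group

A few compounds are considered here, and "the series" means these few. Any claim that something is new, unique, unknown or untested is made for them only; others in the source may bear on it.

In a functional assay on LoVo cells (Homo sapiens) for cytotoxicity, read by MTT assay, with a stated time of 24 h (on this read-out lower numbers stand for stronger inhibition and higher numbers for weaker inhibition), compound 1 (`Cc1ccc(Cl)cc1S(=O)(=O)Nc1ccc(Cl)c(Cl)c1`) gives 55000 nM and compound 2 (`Cc1ccc(NS(=O)(=O)c2cc(Cl)sc2Cl)cc1`) gives 69300 nM on this read-out. These two values lie within the scatter of each other, so compound 2 stands level with compound 1.

Compound 3 (`Cc1ccc(N(SC(Cl)(Cl)Cl)S(=O)(=O)c2cc(Cl)sc2Cl)cc1`) carries (trichloromethyl)sulfanyl in place of hydrogen on a sulfonamide nitrogen and is otherwise compound 2. Among the measured compounds shown here, no measured pair shows this change, so what follows is a judgement with a wide range. A step beyond the scatter is expected in this assay, towards a lower number and so towards stronger inhibition. The estimate means an 8.7-fold lower number from compound 2 to compound 3 (0.94 log units; beyond the scatter) as the expected change. Compound 3 is estimated at 8000 nM with an expected range of 1500 nM to 30000 nM in this assay once measured.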

Compound 3, half-maximal inhibitory concentration: 70300 nM
The estimate for compound 3 lay 8.8-fold (0.94 log units) below the measured number; the measured number lies above the stated range.
By their numbers in this assay, from the lowest: compounds 1, 2 and 3 (each within the scatter of the next).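

On a sulfonamide nitrogen whose other neighbours are an aromatic carbon and a sulfonyl sulfur, (trichloromethyl)sulfanyl in place of hydrogen gives a 1.0-fold higher number from compound 2 to compound 3 (0.01 log units; within the scatter) in this assay, so the two stand level. Compound 1 and compound 2 both keep the hydrogen on that nitrogen, and compound 3 now shows that this hydrogen is not required for this level of cytotoxicity, even with 5 heavy atoms entering in its place. No supporting measurement bears on this result.

Open, going by these compounds, is whether a methyl group or an acetyl group on the same nitrogen would also stand level with compound 2. Also open, on these data alone, is whether (trichloromethyl)sulfanyl on the sulfonamide nitrogen of compound 1 would give a similar step on its own core.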